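Fluoro in place of methyl on the pendant aryl ring

The source may report more compounds than this note shows. Statements on the series, on what has been measured and on what is new or still open speak of the compounds shown alone.

The three measured compounds share a core carrying a hydroxy-substituted cycloalkyl amide and a methylamide. Compound 1 `CNC(=O)c1cc(C(=O)N[C@H]2CC[C@H](O)CC2)n([C@@H](C)c2ccc(Cl)cc2)n1` gives 3.7 in a physicochemical assay for lipophilicity (a higher number here means a more lipophilic compound, a lower number a more polar compound), compound 2 `CNC(=O)c1cc(C(=O)N[C@H]2CC[C@H](O)CC2)c([C@@H](C)c2cccc(C)c2)o1` gives 3.3, and compound 3 `CNC(=O)c1cc(C(=O)N[C@H]2[C@@H]3C[C@@H](O)C[C@@H]32)n([C@@H](C)c2cccc(Cl)c2)n1` gives 3.4. Against compound 1, compound 2 reads lower by a gap beyond the scatter; against compound 3 the gap is within the scatter, so the two cannot be ordered on these numbers.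

Compound 4 `CNC(=O)c1cc(C(=O)N[C@H]2CC[C@H](O)CC2)c([C@@H](C)c2cccc(F)c2)o1` is not yet measured. It differs from compound 2 in one place: fluoro in place of methyl on an aromatic carbon.

Among the compounds with values here, no measured pair in this set isolates this change, so its size is not known from the data. Only a small step is expected for compound 4, directed downward, near the edge of the scatter, as a number 0.30 log units lower from compound 2 to compound 4 (within the scatter). Compound 4 is therefore estimated at 3 in this assay, with a range from 2.7 to 3.3.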

Compound 4, distribution coefficient: 4.1
Estimate against measurement, compound 4: 1.10 log units below; the whole stated range lies below it.
By their numbers in this assay, from the lowest: compounds 2, 3 and 1 (each within the scatter of the next, the first and the last beyond it); then compound 4.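

Within the data shown here, on the pendant aryl ring, going from 3-methylphenyl to 3-fluorophenyl gives, in this assay, a number 0.80 log units higher from compound 2 to compound 4 (beyond the scatter) and so supplies the first step in this set that isolates a single change. It shows that this position, on an aromatic carbon of the six-membered ring, is not silent in this read-out: exchanging one heavy atom for another, with no change in the counted hydrogen-bond donors, acceptors or charge, moves the number upward by more than the scatter. Nothing available here bears on why the number moves in this direction.

The compounds shown leave open whether the same exchange gives a step of like size and direction on the other cores in the set. They also leave open how a methoxy group, a nitrile or an amine at this ring carbon would read in this assay.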